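Thiazole amides: chloro for fluoro on the benzamide arm

The source may hold more compounds than are shown below. What is called first, only, known or untested is meant among the compounds shown, and "the series" means these compounds.

The series shares one core, carrying either a carboxy group or a carbamoyl group. Compound 1 `CN1CCN(c2ccc(Nc3nc(-c4cccc(NC(=O)c5ccccc5F)c4)sc3C(=O)O)cc2)CC1` is the carboxylic acid with the 2-fluorophenyl amide; in a functional assay on Ramos cells (Homo sapiens) for antiproliferative activity, read by CCK-8 assay, with a stated time of 72 h, tested at 40 uM (a higher number here means more inhibition at the concentration tested (going by the name of the read-out), a lower number less inhibition), compound 1 gives 93.4%. Compound 2 `CN1CCN(c2ccc(Nc3nc(-c4cccc(NC(=O)c5ccc(Cl)cc5)c4)sc3C(=O)O)cc2)CC1` carries the 4-chlorophenyl amide on the same acid core; in this assay compound 2 gives 71.6%. The change between them is 4-chlorophenyl in place of 2-fluorophenyl on a carbonyl carbon and it made a step of a number 21.8 percentage points lower from compound 1 to compound 2 (beyond the scatter).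

Compound 3 `CN1CCN(c2ccc(Nc3nc(-c4cccc(NC(=O)c5ccccc5F)c4)sc3C(N)=O)cc2)CC1` is the carbamoyl counterpart of compound 1, differing by amino in place of hydroxy on a carbonyl carbon; in this assay compound 3 gives 95.5%, so the step of a number 2.1 percentage points higher from compound 1 to compound 3 (within the scatter) lies within the usual scatter, and the two acid and amide cores read alike here.

Compound 4 `CN1CCN(c2ccc(Nc3nc(-c4cccc(NC(=O)c5ccc(Cl)cc5)c4)sc3C(N)=O)cc2)CC1` is not yet measured. It differs from compound 3 by 4-chlorophenyl in place of 2-fluorophenyl on a carbonyl carbon, the same change as from compound 1 to compound 2, made at the same place on a carbonyl carbon whose other neighbours are an amide-type nitrogen, but now on the carbamoyl core. Among the measured compounds shown here, because a number 21.8 percentage points lower from compound 1 to compound 2 (beyond the scatter) on the acid core, the same step is expected on the amide core, and a number 21.5 percentage points lower from compound 3 to compound 4 (beyond the scatter) is the estimated size of it, with the single earlier example as the only basis. In this assay compound 4 is therefore expected at about 74%, estimated between 56% and 90%.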

Compound 4, a percentage reported as inhibition, at one concentration (the size of the read-out at that concentration, not a potency): 99%
Estimate against measurement, compound 4: 25 percentage points below, and the stated range ends below it.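

In this assay, 4-chlorophenyl in place of 2-fluorophenyl on a carbonyl carbon does not carry from the acid core to the carbamoyl core, where the change gives a number 3.5 percentage points higher from compound 3 to compound 4 (within the scatter): the same change on two cores in this assay, a number 21.8 percentage points lower (beyond the scatter) from compound 1 to compound 2 and a number 3.5 percentage points higher (within the scatter) from compound 3 to compound 4, 25.3 percentage points apart, beyond the scatter of two such steps. Read the other way, amino in place of hydroxy on a carbonyl carbon separates the two cores only with the 4-chlorophenyl amide, giving a number 27.4 percentage points higher from compound 2 to compound 4 (beyond the scatter): the same change on two cores in this assay, a number 2.1 percentage points higher (within the scatter) from compound 1 to compound 3 and a number 27.4 percentage points higher (beyond the scatter) from compound 2 to compound 4, 25.3 percentage points apart, beyond the scatter of two such steps. This shows that the two changes do not add independently in these four compounds, but it rests on one set of four readings at a single concentration, so it gives neither a rule for other amides or cores, nor a potency order, nor a reason for the gap.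

Open, as far as these compounds go, is whether the lower reading of compound 2 is tied to the chlorine on the acid core, which a plain phenyl on the same carbonyl carbon, or a methyl ester in place of the carboxylic acid, would help to test. Also open, from the compounds shown here alone, is whether the steps that lie within the scatter here would stay so in readings at lower concentrations, where the compounds might separate.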